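A Trifluoromethylsulfonyl Swap at the Cytotoxicity Ceiling

This account rests on a few compounds, and the source may have more. Where it says the series, first, only, none or still open, it means among the compounds named here.

Compound 1 `COc1cc(NC(=O)c2cc(C(F)(F)F)cc(C(F)(F)F)c2)ccc1NS(C)(=O)=O` gives 42000 nM in an ADME assay on HEK293 cells (Homo sapiens) for cytotoxicity, read by MTT assay, with a stated time of 48 h; a lower number here means a stronger inhibitor, a higher number a weaker inhibitor. Compound 3 `CS(=O)(=O)Nc1ccc(NC(=O)c2cc(C(F)(F)F)cc(C(F)(F)F)c2)cc1F` reaches only the upper limit of this assay, reported as > 250000 nM and not as a number. Compound 2 `O=C(Nc1ccc(NS(=O)(=O)C(F)(F)F)c(Cl)c1)c1cc(C(F)(F)F)cc(C(F)(F)F)c1` likewise returns only a limit, > 250000 nM. For the measured compounds named here, the single measured step runs an at least 5.9-fold higher number from compound 1 to compound 3 (0.77 log units; beyond the scatter) and ends at the limit of > 250000 nM in this assay, at which 2 of the 3 values shown sit. Compound 4 `O=C(Nc1ccc(NS(=O)(=O)C(F)(F)F)c(F)c1)c1cc(C(F)(F)F)cc(C(F)(F)F)c1` differs from compound 3 by trifluoromethyl in place of methyl on a sulfonyl sulfur. Going by the values given here, no measured pair carries this change, so the only guidance is that compound 3 already sits where this assay resolves nothing higher. The expected step is therefore a step that the limit leaves unreadable from compound 3 to compound 4, none beyond the scatter. Compound 4 is estimated at 300000 nM, within a range from 150000 nM to 600000 nM, most likely reported again only as a limit.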

Compound 4, half-maximal inhibitory concentration: 164000 nM
The estimate for compound 4 lay 1.8-fold (0.26 log units) above the measured number, and the stated range covers the measured number.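

With trifluoromethyl on the sulfonyl sulfur and fluoro on the aromatic carbon, compound 4 gives a measured number of 164000 nM in this assay and not a limit. Set against compound 3 the change reads as an at least 1.5-fold lower number from compound 3 to compound 4 (0.18 log units; that floor lies within the scatter) and set against compound 2 it reads as an at least 1.5-fold lower number from compound 2 to compound 4 (0.18 log units; that floor lies within the scatter) and both figures are only floors: (the limit of > 250000 nM in this assay, at which 2 of the 4 values shown sit). As far as these compounds go, the true size of either step stays open, as does the reading that an amine or a longer chain on the sulfonyl sulfur would give.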